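The source may report more compounds than this note shows. Statements on the series, on what has been measured and on what is new or still open speak of the compounds shown alone.

compound 1 `COc1ccc(OC)c(C(=O)/C=C/c2ccsc2)c1`: 3800 nM
compound 2 `COc1ccc(OC)c(C(=O)/C=C/c2ccc(OC(=O)/C=C/c3ccc(C)cc3)cc2)c1`: 29700 nM
compound 3 `COc1ccc(/C=C/C(=O)Oc2ccc(/C=C/C(=O)c3cc(OC)ccc3OC)cc2)cc1`: 60400 nM

These numbers come from a functional assay on A549 cells (Homo sapiens) for cytotoxicity, read by MTT assay; a lower number here means a stronger inhibitor, a higher number a weaker inhibitor. Compound 3 gives the highest number of the three, which makes it the weakest inhibitor so far. Compound 4 `COc1ccc(OC)c(C(=O)/C=C/c2ccc(OC(=O)/C=C/c3cc(OC)c(OC)c(OC)c3)cc2)c1` has not been measured yet. It carries 3,4,5-trimethoxyphenyl in place of 4-methoxyphenyl on a double-bonded chain carbon bound to a double-bonded chain carbon.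

Going by the values given here, only one measured step bears on this change, and it also alters that aromatic group: a 2.0-fold higher number from compound 2 to compound 3 (0.31 log units; beyond the scatter), with methoxy in place of methyl on an aromatic carbon. Among the compounds with values here, that step is modest and points toward a weaker inhibitor, but a single step cannot set a firm direction, and no measured pair shows this exact change. The expected outcome is therefore no clear shift, with the estimate being a 1.2-fold lower number from compound 3 to compound 4 (0.08 log units; within the scatter). For compound 4 the estimated value is 50000 nM, with an expected range from 18000 nM to 120000 nM.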

Compound 4, half-maximal inhibitory concentration: 36700 nM
Beside the measured number, compound 4's estimate is 1.4-fold (0.13 log units) above it, and the stated range covers the measured number.
By their numbers in this assay, from the lowest: compound 1; then compounds 2, 4 and 3 (each within the scatter of the next, the first and the last beyond it).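

In this assay the move to 3,4,5-trimethoxyphenyl, with 12 heavy atoms in place of 8, is a 1.6-fold lower number from compound 3 to compound 4 (0.22 log units; within the scatter) and so shows that this place on a double-bonded chain carbon bound to a double-bonded chain carbon can hold the larger group with no change beyond the usual scatter. The comparison with 4-methylphenyl reads the same way, with a 1.2-fold higher number from compound 2 to compound 4 (0.09 log units; within the scatter) as the step. No measurement shown here offers an explanation for these results.

All the aromatic groups compared at this place carry no net charge, so the compounds shown leave open how an amine or a carboxylic acid on that ring would behave. On these data alone, whether a longer chain in place of the methoxy groups would move the number beyond the scatter also remains open.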